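The source may hold more compounds than are shown below. What is called first, only, known or untested is meant among the compounds shown, and "the series" means these compounds.

Compound 3 `CC1(C)C=C(n2ccccc2=O)c2cc(C(=N)NO)ccc2O1` stands lowest of the three numbers in a functional assay (trachea) with Rattus norvegicus as the target; on this read-out higher numbers stand for higher potency (the scale is a negative logarithm) and lower numbers for lower potency: compound 3 gives 5.51, while compound 1 `COc1ccc2c(c1)C(n1ccccc1=O)=CC(C)(C)O2` gives 5.99 and compound 2 `Cc1ccccc1C(=O)c1ccc2c(c1)C(n1ccccc1=O)=CC(C)(C)O2` gives 6.25. Both measured steps into compound 3 run downward, a number 0.48 log units lower from compound 1 to compound 3 (beyond the scatter) and a number 0.74 log units lower from compound 2 to compound 3 (beyond the scatter), whereas a number 0.26 log units higher from compound 1 to compound 2 (within the scatter). Compound 4 `CC(=O)Oc1ccc2c(c1)C(n1ccccc1=O)=CC(C)(C)O2` carries a group of 4 heavy atoms (2 carbon, 2 oxygen; no ring) in place of a group of 4 heavy atoms (1 carbon, 2 nitrogen, 1 oxygen; no ring), on an aromatic carbon. The acetoxy group, like the methoxy of compound 1, joins the aromatic carbon through oxygen, so the step from compound 1 to compound 3 is the closest guide, and a reversal of it is expected rather than a further fall. On that basis the estimated step is a number 0.39 log units higher from compound 3 to compound 4 (beyond the scatter), upward and beyond the scatter. For compound 4 the expected value is 5.9, within a range from 5.4 to 6.4.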

Compound 4, logarithm of the reciprocal of the active concentration, log(1/C): 4.97
Compound 4: middle estimate off by 0.93 log units, on the high side; measured number below the stated range.
By their numbers in this assay, from the lowest: compound 4; then compound 3; then compounds 1 and 2 (each within the scatter of the next).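

At this aromatic carbon, attachment through oxygen does not by itself hold the level in this assay: acetyl in place of methyl on that oxygen gives a number 1.02 log units lower from compound 1 to compound 4 (beyond the scatter). Acetoxy also gives a number 0.54 log units lower from compound 3 to compound 4 (beyond the scatter) and a number 1.28 log units lower from compound 2 to compound 4 (beyond the scatter), which places compound 4 lowest of the four, with its steps to all the others beyond the scatter. No measurement available here accounts for this fall. Open, going by these compounds, is where an amine or a carboxylic acid at this carbon would stand, and whether a longer acyl chain on the oxygen would follow acetyl.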